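A Third Methoxy Group and Its Expected Effect on Cell Growth

This account rests on a few compounds, and the source may have more. Where it says the series, first, only, none or still open, it means among the compounds named here.

Of the compounds shown here, three have so far been tested in a functional assay on HOP-62 cells (Homo sapiens) for cytotoxicity, read by sulforhodamine B assay, with a stated time of 48 h, tested at 0.01 uM; on this read-out lower numbers stand for a stronger effect and higher numbers for a weaker effect at the one concentration tested. Compound 1 `COc1ccc(-c2cc(/C=C/C(=O)c3ccc(N)cc3)[nH]n2)cc1` gives 107%, and compound 2 `COc1ccc(C(=O)/C=C/c2cc(-c3cc(OC)c(OC)c(OC)c3)n[nH]2)cc1OC` gives 101%; these two numbers lie within the usual scatter of each other. How the core of compound 1 and the core of compound 2 differ is not broken down here. Compound 3 `COc1ccc(-c2cc(/C=C/C(=O)c3ccc(N)cc3)[nH]n2)cc1OC` differs from compound 1 in one place, (methoxy in place of hydrogen on an aromatic carbon), and in this assay compound 3 gives 83%. That single change made a number 24 percentage points lower from compound 1 to compound 3 (beyond the scatter).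

Compound 4 `COc1cc(C(=O)/C=C/c2cc(-c3cc(OC)c(OC)c(OC)c3)n[nH]2)cc(OC)c1OC` has not yet been measured. It differs from compound 2 by methoxy in place of hydrogen on an aromatic carbon. Within the data shown here, this is the same kind of change as the one from compound 1 to compound 3, but not the same: in compound 4 the entering group is ortho to a methoxy group, meta to a large group and also meta to a methoxy group, whereas in compound 3 it is ortho to a methoxy group and meta to a large group only. Only one earlier example of this kind of change exists among these compounds, so the expectation is uncertain. Compound 4 is expected to show a step of a number 11 percentage points lower from compound 2 to compound 4 (beyond the scatter), kept somewhat smaller than the earlier one because a number 24 percentage points lower from compound 1 to compound 3 (beyond the scatter) rests on a single pair. In this assay compound 4 is therefore estimated at 90%, most likely falling between 72% and 108%.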

Compound 4, a percentage reported as activity, at one concentration (the size of the read-out at that concentration, not a potency): 97%
Estimate against measurement, compound 4: 7 percentage points below, and the stated range covers the measured number.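

In this assay the added methoxy group gives a number 4 percentage points lower from compound 2 to compound 4 (within the scatter), so on this core the change produces no difference that can be told apart from ordinary repeat variation. Set beside the earlier example, the same change does not carry over at the same size from one core to the other: the same change on two cores in this assay, a number 24 percentage points lower (beyond the scatter) from compound 1 to compound 3 and a number 4 percentage points lower (within the scatter) from compound 2 to compound 4, 20 percentage points apart, beyond the scatter of two such steps This shows that the drop seen on the core of compound 1 cannot simply be assumed on the core of compound 2, but two pairs do not show what sets them apart, as the cores differ and the entering group in compound 4 is also meta to a methoxy group, which the entering group in compound 3 is not.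

The compounds shown leave open whether a different group in the same place, such as a hydroxyl, a chlorine atom or a longer ethoxy chain, would give a clearer step on either core, and whether a third core would side with the large step or the small one. They also leave open how these steps would look at any other concentration, as each number here is a single reading at one concentration and not a potency.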